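This account rests on a few compounds, and the source may have more. Where it says the series, first, only, none or still open, it means among the compounds named here.

Three compounds share one core and differ only in the aromatic group attached to it. In a functional assay on CHO-K1 cells for antagonist activity at adenosine receptor A1 (Homo sapiens), read by a beta-galactosidase reporter and cAMP accumulation, with stated times of 15 min and 6 h (on this read-out higher numbers stand for weaker inhibition and lower numbers for stronger inhibition), compound 3 `Cc1nc(-c2nc(N)c3cc(Cc4ccccc4)sc3n2)cs1` gives 263 nM. Compound 1 `CCc1ccc(-c2nc(N)c3cc(Cc4ccccc4)sc3n2)o1` gives 223 nM, and compound 2 `Nc1nc(-c2ncco2)nc2sc(Cc3ccccc3)cc12` gives 310 nM. The number for compound 3 sits between the other two, and a 1.2-fold higher number from compound 1 to compound 3 (0.07 log units; within the scatter) as well as a 1.2-fold lower number from compound 2 to compound 3 (0.07 log units; within the scatter) stay within the scatter, so the three are indistinguishable here. Compound 4 `Nc1nc(-c2ccccn2)nc2sc(Cc3ccccc3)cc12` carries pyridin-2-yl in place of 2-methyl-1,3-thiazol-4-yl on an aromatic carbon. For the measured compounds named here, no measured step puts a six-membered ring in this place, so the bearing steps are the two swaps among five-membered rings, both small. The expected change is a 1.1-fold higher number from compound 3 to compound 4 (0.06 log units; within the scatter), and compound 4 is estimated at 300 nM, ranging from 120 nM to 750 nM.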

Compound 4, inhibition constant: 3710 nM
Estimate against measurement, compound 4: 12-fold (1.09 log units) below; the whole stated range lies below it.
By their numbers in this assay, from the lowest: compounds 1, 3 and 2 (each within the scatter of the next); then compound 4.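

Swapping among the five-membered rings left the number within the scatter, but the six-membered pyridin-2-yl does not behave like them: the change gives a 14-fold higher number from compound 3 to compound 4 (1.15 log units; beyond the scatter) and a 12-fold higher number from compound 2 to compound 4 (1.08 log units; beyond the scatter) and a 17-fold higher number from compound 1 to compound 4 (1.22 log units; beyond the scatter) in the same direction. This place on the core therefore accepts several five-membered aromatic rings but does not accept every aromatic group of the same heavy-atom count equally. Nothing shown gives a reason for this jump.

As far as these compounds go, whether the jump belongs to six-membered rings in general or to pyridin-2-yl alone remains open. A plain phenyl ring or a pyridin-3-yl group at this place would help to separate the two.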